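Notes on replacing the imidazole group in compound 2

This account rests on a few compounds, and the source may have more. Where it says the series, first, only, none or still open, it means among the compounds named here.

Measured so far in a functional assay on NCI-H460 cells (Homo sapiens) for cytotoxicity, read by MTT assay, with a stated time of 72 h; a higher number here means a weaker inhibitor, a lower number a stronger inhibitor:
- compound 1 `CC(C)(C)c1[nH]cnc1/C=c1\[nH]c(=O)/c(=C/c2cccc(Oc3ccc(F)cc3)c2)[nH]c1=O` gives 4 nM
- compound 2 `O=c1[nH]/c(=C\c2nc[nH]c2C2CC2)c(=O)[nH]/c1=C\c1cccc(Oc2ccc(F)cc2)c1` gives 15.2 nM
- compound 3 `O=C(c1ccc(F)cc1)c1cccc(/C=c2\[nH]c(=O)/c(=C/c3nc[nH]c3C3CC3)[nH]c2=O)c1` gives 2.8 nM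

Compound 2 has the highest number of the three, with both others lower beyond the scatter. Compound 4 `O=c1[nH]/c(=C\c2cccc(Oc3ccc(F)cc3)c2)c(=O)[nH]/c1=C\c1cccnc1` differs from it by pyridin-3-yl in place of 5-cyclopropyl-1H-imidazol-4-yl on a double-bonded chain carbon bound to an aromatic carbon. The closest evidence is cyclopropyl in place of tert-butyl (a 3.8-fold higher number from compound 1 to compound 2 (0.58 log units; beyond the scatter)), a modest step within the group that leaves. The other modest step is (4-fluorophenyl)carbonyl in place of 4-fluorophenoxy (a 5.4-fold lower number from compound 2 to compound 3 (0.73 log units; beyond the scatter)), on a part that compound 4 keeps. Among the compounds with values here, no measured step replaces the whole group, so a higher number, by more than either step, is only an expectation. An estimated 4.6-fold higher number from compound 2 to compound 4 (0.66 log units; beyond the scatter) is expected in this assay with wide uncertainty. Compound 4 is estimated at 70 nM with 15 nM to 350 nM as its expected range.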

Compound 4, half-maximal inhibitory concentration: > 1000 nM
Compound 4 gave a limit, no number; the forecaster's own chance of this, stated with the estimate: 3%; middle value at least 14-fold (1.15 log units) from the limit.
By their numbers in this assay, from the lowest: compounds 3 and 1 (each within the scatter of the next); then compound 2. At a limit, above all of these: compound 4.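

Compound 4 carries a limit, not a number: the limit of > 1000 nM in this assay, at which 1 of the 4 values shown sits.

Changing tert-butyl to cyclopropyl was a modest step, but replacing the whole 5-cyclopropyl-1H-imidazol-4-yl group with pyridin-3-yl is a large one (an at least 65-fold higher number from compound 2 to compound 4 (1.81 log units; beyond the scatter)). Replacing 5-(tert-butyl)-1H-imidazol-4-yl with pyridin-3-yl is also large (an at least 250-fold higher number from compound 1 to compound 4 (2.39 log units; beyond the scatter)), so the loss appears with both imidazole groups shown.

The compounds shown do not separate the change of ring from the loss of the cyclopropyl or tert-butyl group. On these data alone, whether a cyclopropyl on the pyridin-3-yl ring, or a 1H-pyrazol-4-yl group, would restore the low numbers remains open.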